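Ring Size Swap on a Chromone Dithiocarbamate

This account rests on a few compounds, and the source may have more. Where it says the series, first, only, none or still open, it means among the compounds named here.

Measured compounds:
compound 1, `O=c1c(SC(=S)N2CCCCC2)coc2ccccc12`: 17400 nM
compound 2, `O=c1c(Cl)c(CSC(=S)N2CCCCC2)oc2ccccc12`: 770 nM
compound 3, `O=c1c(Cl)c(CSC(=S)N2CCCC2)oc2ccccc12`: 1800 nM

Of the compounds shown here, three have been tested in a functional assay on MDA-MB-435S cells (Homo sapiens) for antiproliferative activity, read by MTT assay, with a stated time of 72 h; a higher number here means a weaker inhibitor, a lower number a stronger inhibitor. Compound 1 gives 17400 nM, the highest number of the three. Compound 2 gives 770 nM, and compound 3 gives 1800 nM. The cores of compound 1 and compound 2 differ, but that difference is not broken down here.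

One change has been measured directly: pyrrolidin-1-yl in place of piperidin-1-yl on a thiocarbonyl carbon, which produced a 2.3-fold higher number from compound 2 to compound 3 (0.37 log units; beyond the scatter).

Compound 4, `O=c1c(SC(=S)N2CCCC2)coc2ccccc12`, is not yet measured. It carries the same change applied to compound 1: pyrrolidin-1-yl in place of piperidin-1-yl on a thiocarbonyl carbon. The surroundings of the change are the same in both pairs, so this is the same change, now made on the core of compound 1 rather than the core of compound 2.

Going by the values given here, the expectation rests on the single measured pair, where the change gave a 2.3-fold higher number from compound 2 to compound 3 (0.37 log units; beyond the scatter), and on compound 1 giving 17400 nM as the starting point. Resting on that one step, the expected change is a 2.2-fold higher number from compound 1 to compound 4 (0.34 log units; beyond the scatter). Compound 4 is thus estimated at 38000 nM, with a likely range from 15000 nM to 90000 nM.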

Compound 4, half-maximal inhibitory concentration: 1900 nM
Compound 4: the middle estimate sits 20-fold (1.30 log units) above what was measured, outside the stated range (below it).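

In this assay, pyrrolidin-1-yl in place of piperidin-1-yl on a thiocarbonyl carbon gave a 9.2-fold lower number from compound 1 to compound 4 (0.96 log units; beyond the scatter), so the change did not carry over from one core to the other. Set beside the earlier step, it runs in the opposite direction: the same change on two cores in this assay, a 2.3-fold higher number (0.37 log units; beyond the scatter) from compound 2 to compound 3 and a 9.2-fold lower number (0.96 log units; beyond the scatter) from compound 1 to compound 4, 21-fold (1.33 log units) apart, beyond the scatter of two such steps. This shows that, for these two pairs, the effect of the swap depends on the core that carries it, so a step measured on the core of compound 2 cannot simply be transferred to the core of compound 1; it does not show which part of the difference between the cores is responsible, or how the swap would behave on any further core.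

The compounds shown leave open whether the opposite directions would persist with other amines on the thiocarbonyl carbon, such as morpholine or diethylamine. They also leave open whether a core carrying only part of the difference between the two cores would follow compound 1 or compound 2.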